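This account rests on a few compounds, and the source may have more. Where it says the series, first, only, none or still open, it means among the compounds named here.

Measured in an assay for binding affinity to dual specificity mitogen-activated protein kinase kinase 4 (Homo sapiens), read by KINOMEscan, tested at 100 nM; a lower number here means a stronger effect, a higher number a weaker effect of the compound at the concentration tested:
compound 1 `CCCS(=O)(=O)Nc1ccc(F)c(C(=O)c2n[nH]c3ncc(-c4cccc(Cl)c4)cc23)c1F` gives 40%
compound 2 `CCCS(=O)(=O)Nc1ccc(F)c(C(=O)c2n[nH]c3ncc(-c4cccc(N)c4)cc23)c1F` gives 1.6%

Compound 2 stands lowest of the two, with compound 1 higher by a step beyond the scatter. Compound 3 `CCCS(=O)(=O)Nc1ccc(F)c(C(=O)c2n[nH]c3ncc(-c4ccc(F)cc4C)cc23)c1F` differs from compound 2 by 4-fluoro-2-methylphenyl in place of 3-aminophenyl on an aromatic carbon. Among the compounds with values here, the one measured step that bears on this, a number 38.4 percentage points lower from compound 1 to compound 2 (beyond the scatter), came from putting amino in place of chloro; compound 3 carries no amino and no other donor or acceptor on that ring, so the number in this assay is expected to climb back by a large step, a number 43.4 percentage points higher from compound 2 to compound 3 (beyond the scatter). Compound 3 is therefore estimated at 45%, within 10% to 90%.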

Compound 3, a percentage reported as activity, at one concentration (the size of the read-out at that concentration, not a potency): 14%
The estimate for compound 3 lay 31 percentage points above the measured number; low and high end bracket the measured number.
By their numbers in this assay, from the lowest: compound 2; then compound 3; then compound 1.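

In this assay, placing 4-fluoro-2-methylphenyl on this aromatic carbon gives a number 12.4 percentage points higher from compound 2 to compound 3 (beyond the scatter), but also a number 26 percentage points lower from compound 1 to compound 3 (beyond the scatter). A ring with 0 hydrogen-bond donors and 0 hydrogen-bond acceptors can therefore still lie below the 3-chlorophenyl ring of compound 1, so losing the amino group does not by itself return the number to that of compound 1. Nothing available explains this order. The compounds shown leave open whether the fluoro or the methyl group separates compound 3 from compound 1, and whether a 3-hydroxyphenyl ring would come close to compound 2.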